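One Linker Swap, Tried on a Second Core

The compounds below may be only part of what the source reports. "The series", "measured", "known", "first", "only" and "open" are said of these compounds alone.

Compound 1, `COc1cc2c(Nc3ccc(OCc4cccc(F)c4)c(Cl)c3)ncnc2cc1OCCCCCn1ccnc1[N+](=O)[O-]`, and compound 2, `COc1cc2c(Nc3ccc(OCc4cccc(F)c4)c(Cl)c3)ncnc2cc1OCCOCCn1ccnc1[N+](=O)[O-]`, share the same core and differ only in the chain that hangs from one of its ring oxygens. In a functional assay on A549 cells (Homo sapiens) for inhibition, read by sulforhodamine B assay, with a stated time of 72 h (a lower number here means a stronger inhibitor, a higher number a weaker inhibitor), compound 1 gives 19900 nM, while compound 2 gives 5060 nM. The change between them is 2-(2-nitro-1H-imidazol-1-yl)ethoxy in place of 3-(2-nitro-1H-imidazol-1-yl)propyl on a saturated chain carbon, two bonds along the chain from an oxygen on an aromatic ring, and it made a 3.9-fold lower number from compound 1 to compound 2 (0.59 log units; beyond the scatter).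

Compound 3, `COc1cc2c(Nc3cccc(Br)c3)ncnc2cc1OCCCCCn1ccnc1[N+](=O)[O-]`, is built on a different core; the difference between the two cores is not broken down here. In this assay compound 3 gives 8780 nM, which sits within the usual scatter of compound 2 and is higher than compound 1 by more than the scatter.

Compound 4, `COc1cc2c(Nc3cccc(Br)c3)ncnc2cc1OCCOCCn1ccnc1[N+](=O)[O-]`, has not yet been measured. It stands to compound 3 exactly as compound 2 stands to compound 1: the change is 2-(2-nitro-1H-imidazol-1-yl)ethoxy in place of 3-(2-nitro-1H-imidazol-1-yl)propyl on a saturated chain carbon, two bonds along the chain from an oxygen on an aromatic ring, and since the place is described in the same words, this is the same change, carried onto a second core. Among the measured compounds shown here, only one earlier example of this change exists, so the expectation rests on that single step. Because a 3.9-fold lower number from compound 1 to compound 2 (0.59 log units; beyond the scatter) was seen on the first core, the corresponding step is expected to be a 2.9-fold lower number from compound 3 to compound 4 (0.47 log units; beyond the scatter), set a little smaller to allow for a thin basis. Compound 4 is therefore estimated to give 3000 nM in this assay, with a plausible range from 1200 nM to 7500 nM.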

Compound 4, half-maximal inhibitory concentration: 13000 nM
Compound 4: middle estimate off by 4.3-fold (0.64 log units), on the low side; measured number above the stated range.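

Carried onto the second core, putting 2-(2-nitro-1H-imidazol-1-yl)ethoxy in place of 3-(2-nitro-1H-imidazol-1-yl)propyl gave a 1.5-fold higher number from compound 3 to compound 4 (0.17 log units; within the scatter) in this assay, so on this core the two chains cannot be told apart. The effect seen on the core of compound 1 therefore did not carry over to the core of compound 3, and the mismatch between the two steps is larger than repeat measurements alone would be expected to produce: the same change on two cores in this assay, a 3.9-fold lower number (0.59 log units; beyond the scatter) from compound 1 to compound 2 and a 1.5-fold higher number (0.17 log units; within the scatter) from compound 3 to compound 4, 5.8-fold (0.77 log units) apart, beyond the scatter of two such steps This shows that, in this small set, the effect of the swap depends on the core it sits on, but it does not show which part of the difference between the cores is responsible, why the two results diverge, or what the swap would do on any third core.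

The compounds shown leave open whether the improvement on the core of compound 1 is specific to this one pair or would also appear with a longer chain ending in the same 2-nitro-1H-imidazol-1-yl group. They also leave open how either core would respond if an amine took the place of that group at the end of the chain.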